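This account rests on a few compounds, and the source may have more. Where it says the series, first, only, none or still open, it means among the compounds named here.

The series rests on two measured compounds. Compound 1, `COc1ccc2[nH]c(-c3ccccc3)c(C=C(C#N)C#N)c2c1`, gives 7000 nM in a functional assay on A549 cells (Homo sapiens) for inhibition, read by sulforhodamine B assay, with a stated time of 48 h; a higher number here means a weaker inhibitor of growth, a lower number a stronger inhibitor of growth. Compound 2, `CC(=O)/C(=C\c1c(-c2ccccc2)[nH]c2ccccc12)S(=O)(=O)c1ccccc1`, gives 7200 nM in this assay, the higher of the two numbers, though its gap to compound 1 lies within the scatter, so the two read as the same.

Compound 3, `O=C(/C(=C\c1c(-c2ccccc2)[nH]c2ccccc12)S(=O)(=O)c1ccccc1)c1ccccc1`, is the next compound, not yet measured. Its change from compound 2 is phenyl in place of methyl on a carbonyl carbon. No measured pair in this set shows this change, so the direction of the step rests on no shown step. Compound 3 is therefore expected to stay close to compound 2, with a step of a 1.2-fold lower number from compound 2 to compound 3 (0.08 log units; within the scatter) that is expected to fall within the scatter rather than beyond it. On that basis compound 3 is estimated at 6000 nM in this assay, expected to lie between 2500 nM and 15000 nM.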

Compound 3, concentration for 50% growth inhibition: 35000 nM
For compound 3 the middle estimate is 5.8-fold (0.77 log units) below the measured one; the measured number lies above the stated range.
By their numbers in this assay, from the lowest: compounds 1 and 2 (each within the scatter of the next); then compound 3.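

Phenyl in place of methyl on a carbonyl carbon gives the first step in this set that can be read, a 4.9-fold higher number from compound 2 to compound 3 (0.69 log units; beyond the scatter) in this assay. Within the data shown here, the two earlier compounds offered no such step, and this one shows that the group on this carbonyl carbon is not indifferent: within this pair, benzoyl goes with weaker growth inhibition than acetyl. No measurement shown here accounts for the loss.

The compounds shown leave open whether the loss belongs to the aromatic ring itself or would also appear with an ethyl or cyclohexyl group, or with an amine, on the same carbonyl carbon. Going by these compounds, it is also open whether acetyl to benzoyl would give a similar step on a core other than that of compound 2.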